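A few compounds are considered here, and "the series" means these few. Any claim that something is new, unique, unknown or untested is made for them only; others in the source may bear on it.

Of the compounds shown here, two have been measured in a functional assay on A549 cells (Homo sapiens) for inhibition, read by sulforhodamine B assay, with a stated time of 48 h; a higher number here means a weaker inhibitor of growth, a lower number a stronger inhibitor of growth. Compound 1 `N#C/C(=C\N1CCN(C(=O)c2ccco2)C1=S)C(N)=O` gives 34500 nM in this assay, while compound 2 `O=CN1CCN(c2ccc(Cl)cc2)C1=S` gives 14800 nM, the lowest of the two numbers and beyond the scatter from compound 1. Compound 3 `O=CN1CCN(c2ccc(Cl)c(Cl)c2)C1=S` differs from compound 2 by a single change: chloro in place of hydrogen on an aromatic carbon. For the measured compounds named here, no measured pair shows this change, so its effect is not known from the data. The expected step is small, a 1.5-fold lower number from compound 2 to compound 3 (0.17 log units; within the scatter), probably downward in this assay but possibly not beyond the scatter. Compound 3 is estimated at 10000 nM, with a range from 4000 nM to 25000 nM.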

Compound 3, concentration for 50% growth inhibition: 17800 nM
Beside the measured number, compound 3's estimate is 1.8-fold (0.25 log units) below it, within the range that was stated.
By their numbers in this assay, from the lowest: compounds 2, 3 and 1 (each within the scatter of the next, the first and the last beyond it).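

In this assay the chloro placed ortho to the existing chloro group gives a 1.2-fold higher number from compound 2 to compound 3 (0.08 log units; within the scatter), so compound 3 and compound 2 stand within the scatter of each other. This first step between measured compounds shows that this aromatic carbon carries a second chloro with no shift beyond the scatter. No supporting measurement bears on this result.

Still open, as far as these compounds go, is whether a methoxy group, an amine or a carboxylic acid at this position would move the number beyond the scatter. Also open, from the compounds shown here alone, is how this step would read on the core of compound 1.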